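The compounds below may be only part of what the source reports. "The series", "measured", "known", "first", "only" and "open" are said of these compounds alone.

Compound 1, `C/C(=C\CC/C(C)=C/CC[C@@H]1[C@@]2(C)CCC(=O)C(C)(C)[C@H]2CC[C@@]1(C)O)CC/C=C(\C)C(=O)OCc1cn(-c2cccc(O)c2)nn1`, gives 146000 nM in an ADME assay on L132 cells (Homo sapiens) for cytotoxicity, read by MTT assay, with a stated time of 48 h; on this read-out lower numbers stand for stronger inhibition and higher numbers for weaker inhibition; this is the only number shown. Compound 2, `C/C(=C\CC/C(C)=C/CC[C@@H]1[C@@]2(C)CCC(=O)C(C)(C)[C@H]2CC[C@@]1(C)O)CC/C=C(\C)C(=O)OCc1cn(-c2ccccc2C(F)(F)F)nn1`, in this assay reaches only the limit > 150000 nM. Among the compounds with values here, the one measured step, an at least 1.0-fold higher number from compound 1 to compound 2 (0.01 log units; that floor lies within the scatter), also swaps out the hydroxy, and the limit of > 150000 nM in this assay, at which 1 of the 2 values shown sits, marks where it stops. Compound 3, `C/C(=C\CC/C(C)=C/CC[C@@H]1[C@@]2(C)CCC(=O)C(C)(C)[C@H]2CC[C@@]1(C)O)CC/C=C(\C)C(=O)OCc1cn(-c2cccc(Cl)c2)nn1`, differs from compound 1 by chloro in place of hydroxy on an aromatic carbon. Because an at least 1.0-fold higher number from compound 1 to compound 2 (0.01 log units; that floor lies within the scatter) stayed within the scatter, a similarly small shift, a 1.1-fold higher number from compound 1 to compound 3 (0.04 log units; within the scatter), is expected for compound 3, with a real chance of a limit. Compound 3 is estimated at 160000 nM, between 80000 nM and 320000 nM.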

Compound 3, half-maximal inhibitory concentration: 94200 nM
Beside the measured number, compound 3's estimate is 1.7-fold (0.23 log units) above it, and the stated range covers the measured number.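

Putting chloro in place of hydroxy on this aromatic carbon gives a 1.5-fold lower number from compound 1 to compound 3 (0.19 log units; within the scatter), so in this assay the number does not depend on the hydroxy being there. Changing the whole aryl group gives an at least 1.5-fold lower number from compound 2 to compound 3 (0.20 log units; that floor lies within the scatter), so this comparison also shows no step beyond the scatter. Compound 2 stays a limit of the assay, not a number: the limit of > 150000 nM in this assay, at which 1 of the 3 values shown sits.

As far as these compounds go, whether an amine or a carboxylic acid at this position would move the number beyond the scatter remains open. So does the effect of a methoxy group there.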